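Amino in Place of Ethoxy: an Expectation for Compound 4

A few compounds are considered here, and "the series" means these few. Any claim that something is new, unique, unknown or untested is made for them only; others in the source may bear on it.

Of the compounds shown here, three have been measured in a functional assay on L1210 cells (Mus musculus) for antiproliferative activity; on this read-out lower numbers stand for lower potency and higher numbers for higher potency (the scale is a negative logarithm). Compound 1 `CCOC(=O)c1[nH]cnc1/N=N/N(C)CCO` gives 3.38. Compound 2 `CCCCN(C)/N=N/c1n[nH]cc1C(=O)OCC` gives 3.16, and compound 3 `CCOC(=O)c1c[nH]nc1/N=N/N(C)C` gives 3.35. The three numbers lie within the usual scatter of one another, so compound 2 cannot be set apart from either neighbour on these values alone.

Among the measured compounds shown here, the one step measured between single-point neighbours runs from compound 2 to compound 3 and reads a number 0.19 log units higher from compound 2 to compound 3 (within the scatter). It concerns a chain on the amine nitrogen and says nothing about the carbonyl end of the molecule.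

Compound 4 `CCCCN(C)/N=N/c1n[nH]cc1C(N)=O` has not been measured. It differs from compound 2 at the carbonyl carbon:

amino in place of ethoxy on a carbonyl carbon

For the measured compounds named here, no measured pair here shows what exchanging ethoxycarbonyl for carbamoyl does, so the expectation rests only on the fact that the shared core and the amine side chain are unchanged. The step expected in this assay is therefore a number 0.04 log units higher from compound 2 to compound 4 (within the scatter), which is no more than the scatter allows in either direction. Compound 4 is estimated at 3.2, with a range from 2.6 to 3.8.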

Compound 4, logarithm of the reciprocal of the active concentration, log(1/C): 3.81
The estimate for compound 4 lay 0.61 log units below the measured number, outside the stated range (above it).
By their numbers in this assay, from the lowest: compounds 2, 3 and 1 (each within the scatter of the next); then compound 4.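

In this assay the carbonyl end of the molecule proves able to move the number: with the shared core and the amine side chain unchanged, amino in place of ethoxy on a carbonyl carbon gives a number 0.65 log units higher from compound 2 to compound 4 (beyond the scatter) and so clears the usual scatter. Among the compounds shown here, the one earlier step, on a chain at the amine nitrogen, stayed within that scatter and said nothing about this end of the molecule, so this pair is the only sign here that the position responds to a change. Nothing available explains why ethoxycarbonyl to carbamoyl has this result, and the step stands as an observation without a known cause.

The exchange swaps a larger chain with no hydrogen-bond donor for a smaller group that has one, and a single pair cannot show which of these differences counts, so a methylamino group, a dimethylamino group or a carboxylic acid on the same carbonyl carbon would be informative. Going by these compounds, it also remains open whether the step carries over to other amine side chains, such as the shorter methyl group of compound 3 or the hydroxyethyl chain of compound 1.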